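Trimming the benzylic aryl group in an antiproliferative series

A few compounds are considered here, and "the series" means these few. Any claim that something is new, unique, unknown or untested is made for them only; others in the source may bear on it.

Of the compounds shown here, three built on a shared core have been tested in a functional assay on PC-3 cells (Homo sapiens) for antiproliferative activity, read by MTT assay, with a stated time of 48 h; a higher number here means a weaker inhibitor, a lower number a stronger inhibitor. Compound 1 `COc1cc(N(Cc2ccccc2)C(=O)CSc2nc3ccccc3s2)cc(OC)c1OC` gives 54100 nM in this assay, while compound 2 `COc1ccc2nc(SCC(=O)N(Cc3ccc(OC)c(O)c3)c3cc(OC)c(OC)c(OC)c3)sc2c1` gives 4110 nM and compound 3 `COc1ccc(CN(C(=O)CSc2nc3ccccc3s2)c2cc(OC)c(OC)c(OC)c2)cc1F` gives 20100 nM. Among these three numbers compound 3 stands second highest: compound 1 is its nearest neighbour, and compound 2 lies furthest from it with the lowest value of the set.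

Among the measured compounds shown here, the one directly comparable step so far runs a 2.7-fold lower number from compound 1 to compound 3 (0.43 log units; beyond the scatter), a modest step that lies beyond the scatter.

Compound 4 `COc1cc(N(Cc2ccc(F)cc2)C(=O)CSc2nc3ccccc3s2)cc(OC)c1OC` differs from compound 3 in one place: 4-fluorophenyl in place of 3-fluoro-4-methoxyphenyl on a saturated chain carbon bound to an amide-type nitrogen. Because the step of a 2.7-fold lower number from compound 1 to compound 3 (0.43 log units; beyond the scatter) was modest, and because compound 4 sits structurally between compound 1 and compound 3, the step in this assay is expected to be small, with the number for compound 4 expected to rise somewhat rather than fall. The expected step is a 1.5-fold higher number from compound 3 to compound 4 (0.17 log units; within the scatter). Compound 4 is therefore estimated to give about 30000 nM in this assay, within a range from 12000 nM to 75000 nM.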

Compound 4, half-maximal inhibitory concentration: 50800 nM
For compound 4 the middle estimate is 1.7-fold (0.23 log units) below the measured one; measured number inside the range.
By their numbers in this assay, from the lowest: compound 2; then compound 3; then compounds 4 and 1 (each within the scatter of the next).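

In this assay the step of a 1.1-fold lower number from compound 1 to compound 4 (0.03 log units; within the scatter) shows that fluoro in place of hydrogen on an aromatic carbon of this group gives nothing that can be told from the scatter, so the phenyl and 4-fluorophenyl groups stand level at this place. Set against that, the step of a 2.5-fold higher number from compound 3 to compound 4 (0.40 log units; beyond the scatter) shows that the lower number of compound 3 is tied to the whole 3-fluoro-4-methoxyphenyl group and is not reached by a fluoro-bearing phenyl ring as such, which narrows what the earlier step from phenyl could be read to mean. Nothing at hand gives a reason for either step.

The 3-fluoro-4-methoxyphenyl and 4-fluorophenyl groups differ both in the methoxy and in the number at which the fluoro stands, so the compounds shown cannot assign the step to one of these, and a 4-methoxyphenyl or a 3-fluorophenyl group on the same carbon would be needed to separate them. Also open, from the compounds shown here alone, is what a 4-aminophenyl group, a 4-carboxyphenyl group or a longer chain between the ring and the amide-type nitrogen would give in this assay at this place.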